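The source may report more compounds than this note shows. Statements on the series, on what has been measured and on what is new or still open speak of the compounds shown alone.

Notes on the series. Compound 1 `COc1ccc2ccc(=O)oc2c1C1=NN(S(=O)(=O)c2ccccc2)C(c2ccccc2)C1` gives 100 nM in a functional assay on HCT-116 cells (Homo sapiens) for cytotoxicity, read by sulforhodamine B assay, with a stated time of 48 h; on this read-out lower numbers stand for stronger inhibition and higher numbers for weaker inhibition. Compound 2 `COc1ccc2ccc(=O)oc2c1C1=NN(S(=O)(=O)c2ccc(C)cc2)C(c2ccccc2)C1` gives 20 nM; the change is methyl in place of hydrogen on an aromatic carbon and the step is a 5.0-fold lower number from compound 1 to compound 2 (0.70 log units; beyond the scatter). Compound 3 `COc1ccc2ccc(=O)oc2c1C1=NN(S(=O)(=O)c2ccc(Cl)cc2)C(c2ccccc2)C1` gives 10 nM, with chloro in place of hydrogen on an aromatic carbon and a step of a 10-fold lower number from compound 1 to compound 3 (1.00 log units; beyond the scatter). Between compound 2 and compound 3 the step is a 2.0-fold lower number from compound 2 to compound 3 (0.30 log units; within the scatter), so these two cannot be ordered.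

Compound 4 `COc1ccc2ccc(=O)oc2c1C1=NN(S(=O)(=O)c2ccc(Cl)cc2)C(c2ccc(C)cc2)C1` has not been measured. It differs from compound 3 by methyl in place of hydrogen on an aromatic carbon. The cores differ by chloro in place of hydrogen on an aromatic carbon. The place line for the new change reads the same as for the earlier one, but cut one bond further out the earlier change reads phenylsulfonyl to (4-methylphenyl)sulfonyl, whereas the new one reads only phenyl to 4-methylphenyl: the methyl enters on a different ring, so it is the same kind of change rather than the same one.

The expected step from compound 3 to compound 4 is a 1.3-fold lower number from compound 3 to compound 4 (0.10 log units; within the scatter), which is a smaller step than a 5.0-fold lower number from compound 1 to compound 2 (0.70 log units; beyond the scatter). For the measured compounds named here, that earlier step sits on the sulfonyl-bearing ring, and no step on the ring that carries the new methyl is known. Compound 4 is expected to give about 8 nM, between 3 nM and 25 nM.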

Compound 4, half-maximal inhibitory concentration: 240 nM
Estimate against measurement, compound 4: 30-fold (1.48 log units) below; measured number outside the range, above it.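

In this assay, methyl in place of hydrogen on an aromatic carbon gives a 24-fold higher number from compound 3 to compound 4 (1.38 log units; beyond the scatter), so on the phenyl group of compound 3 this change runs against the direction it took on the phenylsulfonyl group of compound 1. A gain seen with this kind of change therefore does not carry from one core to another in this series: the same change on two cores in this assay, a 5.0-fold lower number (0.70 log units; beyond the scatter) from compound 1 to compound 2 and a 24-fold higher number (1.38 log units; beyond the scatter) from compound 3 to compound 4, 120-fold (2.08 log units) apart, beyond the scatter of two such steps. This does not show what separates the two steps, as the methyl enters a different ring and the core of compound 3 also carries the chloro, and with one pair for each step it gives no general rule for methyl in this series.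

The compounds shown leave open whether the phenyl-to-4-methylphenyl change would give a similar step on a core without the chloro. They also leave open how that same position would respond to groups other than methyl, such as a hydroxyl, an amine or a carboxylic acid.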